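The source may hold more compounds than are shown below. What is called first, only, known or untested is meant among the compounds shown, and "the series" means these compounds.

Working notes on the series, read in a functional assay on MGC-803 cells (Homo sapiens) for inhibition, read by sulforhodamine B assay; on this read-out higher numbers stand for weaker inhibition and lower numbers for stronger inhibition. Compound 3 `O=C1C(Nc2ccc(C(F)(F)F)cc2)=CC(=O)c2c1nc1n2[C@H]2OC[C@@H](O)[C@H]2OC1` gives 1860 nM and compound 2 `Cc1ccc(NC2=CC(=O)c3c(nc4n3[C@H]3OC[C@@H](O)[C@H]3OC4)C2=O)cc1` gives 1550 nM, so a 1.2-fold higher number from compound 2 to compound 3 (0.08 log units; within the scatter) leaves the two level. Compound 1 `O=C1C(NC2CCCC2)=CC(=O)c2c1nc1n2[C@H]2OC[C@@H](O)[C@H]2OC1` reads > 16000 nM, which is a limit and not a number.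

Compound 4 `O=C1C(NC2CCCCC2)=CC(=O)c2c1nc1n2[C@H]2OC[C@@H](O)[C@H]2OC1` carries cyclohexyl in place of 4-(trifluoromethyl)phenyl on an amine nitrogen, with cyclohexyl in place of 4-(trifluoromethyl)phenyl on an amine nitrogen. The closest measured evidence is the cyclopentyl of compound 1, with an at least 10-fold lower number from compound 1 to compound 2 (1.01 log units; beyond the scatter) and an at least 8.6-fold lower number from compound 1 to compound 3 (0.93 log units; beyond the scatter). Both steps are beyond the scatter, so the reverse kind of change should give a higher number of similar size. The expected shift is a 7.5-fold higher number from compound 3 to compound 4 (0.88 log units; beyond the scatter). For compound 4 the estimated value is 14000 nM, with an expected range of 5000 nM to 30000 nM.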

Compound 4, half-maximal inhibitory concentration: > 8000 nM
Compound 4: only a limit was reported; the forecaster's own chance of this, stated with the estimate: 50%; the middle value lies beyond the limit too.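

Replacing either aromatic group with cyclohexyl on the amine nitrogen gives an at least 4.3-fold higher number from compound 3 to compound 4 (0.63 log units; beyond the scatter) and an at least 5.1-fold higher number from compound 2 to compound 4 (0.71 log units; beyond the scatter). The weak reading of compound 1 is therefore not confined to the five-membered cyclopentyl ring: a six-membered ring of carbon also reads weaker than the aromatic rings of compound 2 and compound 3 when it is non-aromatic. Compound 4 gives only a limit, not a number, and the step between compound 1 and compound 4 cannot be read.

Still open, as far as these compounds go, is where an open chain such as n-butyl, or a benzyl group, would fall on this amine nitrogen. Also open, from the compounds shown here alone, is whether a phenyl ring carrying a carboxylic acid or an amine would stay level with compound 2 and compound 3.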